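The compounds below may be only part of what the source reports. "The series", "measured", "known", "first", "only" and "open" are said of these compounds alone.

The measured compounds:
compound 1, `CC(C)NC(=S)N/N=C1\CC(c2ccc(O)cc2)Oc2cc(O)ccc21`, in a functional assay on HeLa cells (Homo sapiens) for cytotoxicity, read by MTT assay, with a stated time of 72 h; on this read-out higher numbers stand for weaker inhibition and lower numbers for stronger inhibition: 68100 nM
compound 2, `Oc1ccc(C2C/C(=N\NC(=S)N3CCCCC3)c3ccc(O)cc3O2)cc1`, in this assay: 74400 nM

The account follows the step from compound 2 to compound 3. Compound 2 stands alongside compound 1 on the numbers shown: a 1.1-fold higher number from compound 1 to compound 2 (0.04 log units; within the scatter), so the two cannot be told apart in this assay. Compound 3, `Oc1ccc(C2C/C(=N\NC(=S)N3CCCC3)c3ccc(O)cc3O2)cc1`, has not yet been measured. It differs from compound 2 in one place: pyrrolidin-1-yl in place of piperidin-1-yl on a thiocarbonyl carbon. For the measured compounds named here, the only measured step that bears on this change is the one at the same thiocarbonyl carbon, a 1.1-fold higher number from compound 1 to compound 2 (0.04 log units; within the scatter), where exchanging isopropylamino for piperidin-1-yl left the number inside the scatter. The change from compound 2 to compound 3 is of the same kind, at the same place, so no step beyond the scatter is expected in this assay in either direction. Compound 3 is therefore expected to give about 72000 nM in this assay, in a range from 36000 nM to 145000 nM, resting on the value of compound 2, 74400 nM. This estimate means an expected step of a 1.0-fold lower number from compound 2 to compound 3 (0.01 log units; within the scatter).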

Compound 3, half-maximal inhibitory concentration: 65200 nM
The estimate for compound 3 lay 1.1-fold (0.04 log units) above the measured number, within the range that was stated.
By their numbers in this assay, from the lowest: compounds 3, 1 and 2 (each within the scatter of the next).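

For the compounds shown here, compound 3 brings the first change of ring size on the thiocarbonyl carbon: in this assay the five-membered pyrrolidin-1-yl in place of the six-membered piperidin-1-yl stays within the scatter (a 1.1-fold lower number from compound 2 to compound 3 (0.06 log units; within the scatter)). Pyrrolidin-1-yl in place of isopropylamino also stays within the scatter (a 1.0-fold lower number from compound 1 to compound 3 (0.02 log units; within the scatter)), so isopropylamino, piperidin-1-yl and pyrrolidin-1-yl, the three groups shown on this carbon, cannot be told apart in this assay and the earlier single step now has two further steps beside it. No supporting measurement is available to explain why these exchanges leave the number where it is.

The compounds leave open whether a different kind of group on the thiocarbonyl carbon, such as an unsubstituted amino group, a phenylamino group or a morpholin-4-yl ring, would give a step beyond the scatter. They also leave open what a change elsewhere in the shared core would do, for example replacing a hydroxyl group with a methoxy group, since all three compounds differ only on the thiocarbonyl carbon.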